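The source may hold more compounds than are shown below. What is called first, only, known or untested is meant among the compounds shown, and "the series" means these compounds.

Measured so far in a toxicity assay on MT2 cells (Homo sapiens) for cytotoxicity, read by MTT assay; on this read-out higher numbers stand for lower toxicity in this test and lower numbers for higher toxicity in this test:

compound 1, `N#Cc1ccc2c(F)cc(Oc3ccccc3OCCn3ccc(=O)[nH]c3=O)c(Cl)c2c1`, gives > 100000 nM, which is a limit of the assay and not a number.
compound 2, `Cc1c(Oc2ccccc2OCCn2ccc(=O)[nH]c2=O)cc(F)c2ccc(C#N)cc12`, gives > 100000 nM, again a limit and not a number.
compound 3, `Cc1c(Oc2ccc(F)cc2OCCn2ccc(=O)[nH]c2=O)cc(Cl)c2ccc(C#N)cc12`, gives 82000 nM, the only number in the set.

Compound 1 and compound 2 differ by one change, (methyl in place of chloro on an aromatic carbon). The step that the two limits leave unreadable from compound 1 to compound 2 cannot be sized, since both values sit at the limit of > 100000 nM in this assay, at which 2 of the 3 values shown sit. All that the pair shows is that neither compound reaches a readable cytotoxic concentration in this assay.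

Compound 3 carries a different core from compound 1; the difference between the two cores is not broken down here.

Compound 4, `Cc1cc(Oc2ccc(F)cc2OCCn2ccc(=O)[nH]c2=O)c(C)c2cc(C#N)ccc12`, is not yet measured. It differs from compound 3 by methyl in place of chloro on an aromatic carbon. This is the same kind of change as that from compound 1 to compound 2, but the surroundings differ: in the first pair the carbon is ortho to a large group and para to a fluoro group, in the second it is meta to a large group and para to a methyl group.

For compound 4 in this assay a step of a 1.1-fold higher number from compound 3 to compound 4 (0.04 log units; within the scatter) is expected, resting on compound 3 at 82000 nM and on the unreadable step between compound 1 and compound 2, which gave no sign that this kind of change moves the read-out. Compound 4 is therefore estimated at 90000 nM, with a likely span from 40000 nM to 200000 nM, and a fair chance that only a limit is reported.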

Compound 4, half-maximal cytotoxic concentration: > 100000 nM
Compound 4 ended at the assay's limit; the forecaster's own chance of this, stated with the estimate: 50%; middle value at least 1.1-fold (0.04 log units) away from the limit.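

In this assay, methyl in place of chloro on an aromatic carbon gives an at least 1.2-fold higher number from compound 3 to compound 4 (0.08 log units; that floor lies within the scatter); this is a floor set by a limit of the assay, not a measured size, and it lies within the scatter, so it does not separate the two compounds. The same change on the core of compound 1 cannot be read, leaving no size to set against the floor on the core of compound 3, so the notes show neither that the change carries over from one core to the other with a similar effect nor that it fails to do so. The series offers little room for such a comparison because nearly all of its values stop at the same limit: the limit of > 100000 nM in this assay, at which 3 of the 4 values shown sit.

Still open, on these data alone, is whether this change has any real effect on the read-out in either core, as compound 3 alone carries a number and the true values behind the limits remain unknown. Also open, as far as these compounds go, is whether an amine, a carboxylic acid or a longer chain on that same aromatic carbon, in place of chloro or methyl, would give a readable number in this assay on either core.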